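A few compounds are considered here, and "the series" means these few. Any claim that something is new, unique, unknown or untested is made for them only; others in the source may bear on it.

Compound 1 `O=S(=O)(Nc1ccc(Cl)cc1)c1ccc(Cl)cc1` gives 8.3 in an ADME assay. Compound 2 `O=S(=O)(Nc1ccc(Cl)cc1)c1ccc(Br)cc1` gives 8.24.

Compound 1 stands highest of these two numbers, and its nearest neighbour is compound 2, with a number 0.06 log units lower from compound 1 to compound 2 (within the scatter). Compound 3 `Nc1ccc(NS(=O)(=O)c2ccc(Cl)cc2)cc1` is not yet measured. It differs from compound 1 by amino in place of chloro on an aromatic carbon. Among the compounds with values here, the only measured step, halogen for halogen on the other ring, does not bear on an amino entering, so no measured step guides this change. Compound 3 is expected to show a number 0.70 log units higher from compound 1 to compound 3 (beyond the scatter), an upward step beyond the scatter, with wide uncertainty. Compound 3 is estimated at 9, in the range 8.4 to 9.6.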

Compound 3, acid dissociation constant: 9.76
Compound 3: the middle estimate sits 0.76 log units below what was measured; measured number above the stated range.
By their numbers in this assay, from the lowest: compounds 2 and 1 (each within the scatter of the next); then compound 3.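

At the place para to a large group, amino in place of chloro gives a number 1.46 log units higher from compound 1 to compound 3 (beyond the scatter) in this assay and so moves the number far more than the halogen exchange did. The earlier pair, differing only by bromo for chloro, could not show that a single change on the core can carry the number beyond the scatter. Nothing available explains the size of this step. On these data alone, whether a hydroxyl, a methoxy or an acetamido group at this place would move the number in the same direction remains open. So does the effect of an amino group on the other ring.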